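Changing the sulfur group on a weak growth inhibitor

The compounds below may be only part of what the source reports. "The series", "measured", "known", "first", "only" and "open" are said of these compounds alone.

For the measured compounds named here, in a functional assay on SMMC-7721 cells (Homo sapiens) for inhibition, read by CCK-8 assay, with a stated time of 72 h, tested at 8 uM (a lower number here means less inhibition of growth, a higher number more inhibition of growth at the concentration tested), compound 1 `Cc1cc(C)cc(SCc2ccc(/C=C/C(=O)Nc3ccccc3N)cc2)c1` gives 7.13%, the lowest of the three numbers known so far. Compound 2 `COc1ccc(SCc2ccc(C(=O)Nc3ccccc3N)cc2)cc1` gives 80.1% and compound 3 `Nc1ccccc1NC(=O)c1ccc(CSc2cccc(F)c2)cc1` gives 83%, both far higher, but these two share a core that differs from the core of compound 1.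

The next molecule, compound 4 `Nc1ccccc1NC(=O)/C=C/c1ccc(CSc2cccc3ccccc23)cc1`, keeps the core of compound 1 and changes only the group on the sulfur: naphthalen-1-yl in place of 3,5-dimethylphenyl on a sulfur. Put simply, naphthalen-1-yl takes the place of 3,5-dimethylphenyl.

Going by the values given here, only one measured step exchanges a group at a comparable place, with 3-fluorophenyl in place of 4-methoxyphenyl on a sulfur: a number 2.9 percentage points higher from compound 2 to compound 3 (within the scatter). That step is small, but it was measured on the other core and with other groups, so it is only a loose guide. Among the compounds with values here, no measurement yet shows what naphthalen-1-yl does on the core of compound 1.

The expectation is therefore no change beyond the scatter, with some room for a larger rise. The estimated step is a number 6.9 percentage points higher from compound 1 to compound 4 (within the scatter). The expected value for compound 4 is 14%, with an estimated range from 3% to 40%.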

Compound 4, percent growth inhibition at one concentration: 18.3%
For compound 4 the middle estimate is 4.3 percentage points below the measured one; the measured number falls inside the stated range.
By their numbers in this assay, from the lowest: compound 1; then compound 4; then compounds 2 and 3 (each within the scatter of the next).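

For the compounds shown here, measured in this assay the exchange of 3,5-dimethylphenyl for naphthalen-1-yl on the sulfur gives a number 11.2 percentage points higher from compound 1 to compound 4 (beyond the scatter) and so provides the first direct evidence that the group at this place can change the number on the core of compound 1. The step is modest, and compound 4 at 18.3% still shows little growth inhibition at the concentration tested, so this exchange alone does not turn the weak inhibitor into a strong one. Neither group has hydrogen-bond donors or acceptors and neither carries a net charge, but the entering group has two six-membered aromatic rings of carbon where the leaving group has one, and no measurement here explains the higher number.

The compounds shown leave open whether other groups on this sulfur, such as naphthalen-2-yl, a simple butyl chain or a ring bearing a carboxylic acid or an amine, would move the number further on this core. They also leave open whether naphthalen-1-yl would give a similar step on the core shared by compound 2 and compound 3.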